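This account rests on a few compounds, and the source may have more. Where it says the series, first, only, none or still open, it means among the compounds named here.

Measured so far:
compound 1 `COc1ccc(/C=C/C(=O)OC[C@@H](OCc2ccccc2)[C@H]2OC(=O)C=C[C@H]2OCc2ccccc2)cc1`: in an ADME assay on MRC5 cells (Homo sapiens) for cytotoxicity, read by MTT assay, with a stated time of 6 days (a higher number here means a weaker inhibitor, a lower number a stronger inhibitor), compound 1 gives > 100000 nM, which is a limit of the assay and not a number.
compound 2 `O=C1C=C[C@@H](OCc2ccccc2)[C@@H]([C@@H](COC(=O)/C=C/c2ccc(F)cc2)OCc2ccccc2)O1`: in this assay compound 2 gives > 100000 nM, again a limit and not a number.
compound 3 `COc1ccc(/C=C/C(=O)OC[C@@H](OC(C)=O)[C@H]2OC(=O)C=C[C@H]2OC(C)=O)cc1`: in this assay compound 3 gives 78000 nM, the only real number among the three.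

Compound 1 and compound 2 share one core and differ by fluoro in place of methoxy on an aromatic carbon. The step between them, a step that the two limits leave unreadable from compound 1 to compound 2, cannot be sized because of the limit of > 100000 nM in this assay, at which 2 of the 3 values shown sit. Compound 3 is built on a different core; how that core differs from the core of compound 1 is not broken down here.

Compound 4 `CC(=O)O[C@@H]1C=CC(=O)O[C@@H]1[C@@H](COC(=O)/C=C/c1ccc(F)cc1)OC(C)=O` has not yet been measured. Among the measured compounds shown here, it differs from compound 3 by fluoro in place of methoxy on an aromatic carbon, the same change, at the same place, as the one between the earlier pair. That earlier change left no readable step, so nothing points to a move in either direction. For compound 4 the expected step is a 1.1-fold higher number from compound 3 to compound 4 (0.04 log units; within the scatter), resting on the unreadable a step that the two limits leave unreadable from compound 1 to compound 2. Compound 4 is therefore estimated at 85000 nM, in a range from 40000 nM to 200000 nM.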

Compound 4, half-maximal inhibitory concentration: > 100000 nM
Compound 4 was reported as a limit; the forecaster's own chance of this, stated with the estimate: 40%; middle value at least 1.1-fold (0.07 log units) from the limit.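

In this assay, putting fluoro in place of methoxy on the core of compound 3 gives an at least 1.2-fold higher number from compound 3 to compound 4 (0.10 log units; that floor lies within the scatter). On these data alone, compound 4 gives > 100000 nM, which is a limit of the assay and not a number, so that step is only a floor and the true size of the change on this core stays unknown. The result shows nothing about whether the change behaves alike on the two cores, since the same change on the core of compound 1 cannot be read, and the two steps cannot be set side by side because so many values stop at the same limit: the limit of > 100000 nM in this assay, at which 3 of the 4 values shown sit.

Still open, as far as these compounds go, is how other groups on that aromatic carbon, such as an amine or a carboxylic acid, would read in this assay. Also open, from the compounds shown here alone, is whether a longer chain on the core of compound 3 would give values that can be read as numbers rather than limits.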